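Dichlorophenyl to oxazolyl on the naphthyl amide carbonyl

A few compounds are considered here, and "the series" means these few. Any claim that something is new, unique, unknown or untested is made for them only; others in the source may bear on it.

Three compounds have been measured in an assay on LtK cells with ATP-sensitive inward rectifier potassium channel 11 (Homo sapiens) as the target; a higher number here means that more compound is needed for the effect, a lower number that less compound is needed:
Compound 1, `O=C(Nc1c(C(O)(C(F)(F)F)C(F)(F)F)ccc2ccccc12)C1CC1`, gives 751 nM.
Compound 2, `COc1ccc(C(=O)Nc2c(C(O)(C(F)(F)F)C(F)(F)F)ccc3ccccc23)cc1`, gives 417 nM.
Compound 3, `O=C(Nc1c(C(O)(C(F)(F)F)C(F)(F)F)ccc2ccccc12)c1cccc(Cl)c1Cl`, reaches only the limit of the assay, > 10000 nM.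

Compound 3 thus stands on (the limit of > 10000 nM in this assay, at which 1 of the 3 values shown sits), with no number of its own, well apart from the other two. The steps of an at least 13-fold higher number from compound 1 to compound 3 (1.12 log units; beyond the scatter) and an at least 23-fold higher number from compound 2 to compound 3 (1.37 log units; beyond the scatter) were both large, whereas a 1.8-fold lower number from compound 1 to compound 2 (0.26 log units; within the scatter) was not. Compound 4, `O=C(Nc1c(C(O)(C(F)(F)F)C(F)(F)F)ccc2ccccc12)c1cnco1`, differs from compound 3 by 1,3-oxazol-5-yl in place of 2,3-dichlorophenyl on a carbonyl carbon. Among the measured compounds shown here, with the dichlorophenyl group leaving again, compound 4 is expected to show an at least 6.6-fold lower number from compound 3 to compound 4 (0.82 log units; beyond the scatter), a move back toward the numbers of compounds 1 and 2, although no measured step covers the oxazolyl itself. Compound 4 is therefore estimated at 1500 nM in this assay, with a range from 400 nM to 6000 nM.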

Compound 4, half-maximal effective concentration: 24 nM
Beside the measured number, compound 4's estimate is 63-fold (1.80 log units) above it, and the stated range ends above it.
By their numbers in this assay, from the lowest: compound 4; then compounds 2 and 1 (each within the scatter of the next). At a limit, above all of these: compound 3.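

In this assay, 1,3-oxazol-5-yl on this carbonyl carbon gives a clearly lower number than either earlier group that had a measured value: a 31-fold lower number from compound 1 to compound 4 (1.50 log units; beyond the scatter) and a 17-fold lower number from compound 2 to compound 4 (1.24 log units; beyond the scatter). Among the compounds shown here, compounds 1 to 3 showed only one large change at this position, upward, whereas an at least 410-fold lower number from compound 3 to compound 4 (2.61 log units; beyond the scatter) shows how far a single replacement here can move the number. The value of compound 3 remains a limit of the assay: the limit of > 10000 nM in this assay, at which 1 of the 4 values shown sits.

Which of the two ring hetero atoms matters stays open. So does whether a thiazole or an imidazole in place of 1,3-oxazol-5-yl would keep the number this low.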